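Swapping a Hydroxy for a Methyl on a Weak Inhibitor

The source may hold more compounds than are shown below. What is called first, only, known or untested is meant among the compounds shown, and "the series" means these compounds.

For the measured compounds named here, compound 2 `CC(O)(C(=O)Nc1ccc(C(=O)c2ccccc2)cc1O)C(F)(F)F` is the only compound with a numeric result in a functional assay (Cavia porcellus) with sulfonylurea receptors; K-ATP channels (Homo sapiens) as the target (on this read-out higher numbers stand for weaker inhibition and lower numbers for stronger inhibition), where compound 2 gives 15000 nM. Compound 1 `CC(O)(C(=O)Nc1ccc(S(=O)(=O)c2ccccc2)c(C(=O)O)c1)C(F)(F)F` gives > 30000 nM, which is a limit of the assay rather than a number. Compound 3 `Cc1cc(C(=O)c2ccccc2)ccc1NC(=O)C(C)(O)C(F)(F)F` differs from compound 2 by methyl in place of hydroxy on an aromatic carbon. Going by the values given here, no measured pair shows this change, so no step beyond the usual scatter is expected in either direction. Compound 3 is therefore expected at 15000 nM, with a range from 5000 nM to 45000 nM. The expected step is no change at the digits printed from compound 2 to compound 3 (within the scatter).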

Compound 3, half-maximal inhibitory concentration: 5000 nM
Estimate against measurement, compound 3: 3.0-fold (0.48 log units) above; the measured number falls inside the stated range.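

On the aromatic carbon ortho to a large group, hydroxy is not required for inhibition in this assay: placing methyl there gives a 3.0-fold lower number from compound 2 to compound 3 (0.48 log units; beyond the scatter). In this one pair, a lower number and thus stronger inhibition comes with 0 hydrogen-bond donors and 0 hydrogen-bond acceptors on the entering group. Nothing shown accounts for this step.

Still open, from the compounds shown here alone, is whether the stronger inhibition belongs to methyl itself or to the loss of hydroxy, and how a methoxy group, an amine or a longer chain would read at this place.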